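The source may report more compounds than this note shows. Statements on the series, on what has been measured and on what is new or still open speak of the compounds shown alone.

Within the data shown here, compound 2 `COC(=O)c1scc(-c2ccc(NC(=O)c3cccc(C(F)(F)F)c3)cc2)c1OC` is one of two compounds measured so far; the other is compound 1 `COC(=O)c1scc(-c2ccc(NC(=O)c3ccc(OC)nc3)cc2)c1OC`. In a functional assay on HepG2 cells (Homo sapiens) for antiproliferative activity, read by MTT assay, with a stated time of 24 h (a lower number here means a stronger inhibitor, a higher number a weaker inhibitor), compound 1 reaches only the limit of the assay, > 50000 nM, which is not a number. In this assay, among the measured compounds shown here, compound 2 gives 32500 nM, the only actual number in hand, so it stands alone as a measured point. The value of compound 1 is a limit (the limit of > 50000 nM in this assay, at which 1 of the 2 values shown sits). For the measured compounds named here, the one measured step, an at least 1.5-fold lower number from compound 1 to compound 2 (0.18 log units; that floor lies within the scatter), comes from exchanging one whole aromatic group for another, 3-(trifluoromethyl)phenyl in place of 6-methoxypyridin-3-yl on a carbonyl carbon.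

Compound 3 `COC(=O)c1scc(-c2ccc(NC(=O)c3cccc(OC(F)(F)F)c3)cc2)c1OC` is not yet measured. It differs from compound 2 by trifluoromethoxy in place of trifluoromethyl on an aromatic carbon. Going by the values given here, no measured step involves this kind of swap; the step from compound 1 to compound 2 changed a whole ring and so bears only loosely on it. The expectation is therefore a step of a 1.1-fold lower number from compound 2 to compound 3 (0.03 log units; within the scatter), that is, nothing beyond the scatter. For compound 3 the estimated value in this assay is 30000 nM, with a range from 12000 nM to 80000 nM.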

Compound 3, half-maximal inhibitory concentration: 720 nM
Estimate against measurement, compound 3: 42-fold (1.62 log units) above, outside the stated range (below it).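

The swap of trifluoromethyl for trifluoromethoxy, on an aromatic carbon meta to a large group, gives a 45-fold lower number from compound 2 to compound 3 (1.65 log units; beyond the scatter) in this assay, so this position responds strongly to a change far smaller than exchanging a whole aromatic group. Among these compounds, the earlier step from compound 1 to compound 2 could not show this, since it replaced an entire ring and its size could be read only from a limit, so the present pair is the first clean comparison at a single place on the shared core. Among the compounds shown here, nothing measured so far accounts for the size of this step, and the presence of an oxygen in trifluoromethoxy and its absence in trifluoromethyl is a difference in the structures, not an explanation.

A single pair cannot tell whether other groups at this place, such as a nitrile, an amine or a difluoromethoxy group, would follow compound 3 or stay close to compound 2. As far as these compounds go, it also remains open whether the same step would appear with the rest of the core altered, or in cells other than those of this one assay.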